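The compounds below may be only part of what the source reports. "The series", "measured", "known", "first", "only" and "open" are said of these compounds alone.

Compound 2 `COc1nc2ccc(Br)cc2cc1C(c1ccccc1)n1cc(-c2ccccc2C(F)(F)F)nn1` stands lowest of the two numbers measured in an ADME assay on HeLa cells (Homo sapiens) for cytotoxicity, read by sulforhodamine B assay, with a stated time of 48 h, tested at 10 uM (on this read-out higher numbers stand for more inhibition at the one concentration tested (going by the name of the read-out) and lower numbers for less inhibition), where compound 2 gives -1.3%, while compound 1 `CCCCCCCc1cn(C(c2ccccc2)c2cc3cc(Br)ccc3nc2OC)nn1` gives 9.7%, a step of a number 11 percentage points lower from compound 1 to compound 2 (beyond the scatter). The next compound, compound 3 `COc1nc2ccc(Br)cc2cc1C(c1ccccc1)n1cc(-c2cccc(F)c2)nn1`, differs from compound 2 by 3-fluorophenyl in place of 2-(trifluoromethyl)phenyl on an aromatic carbon. For the measured compounds named here, the one measured step swapped heptyl for an aromatic group and is only a loose guide to swapping one aromatic group for another. With both measured values low, compound 3 is expected to stay within the scatter of compound 2, with an estimated step of a number 4.3 percentage points higher from compound 2 to compound 3 (within the scatter). Compound 3 is thus estimated at 3%, within -8% to 14%.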

Compound 3, a percentage reported as inhibition, at one concentration (the size of the read-out at that concentration, not a potency): 9.04%
The estimate for compound 3 lay 6 percentage points below the measured number, within the range that was stated.
By their numbers in this assay, from the lowest: compound 2; then compounds 3 and 1 (each within the scatter of the next).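

On this position on the five-membered ring, the choice between two aromatic groups moves the number by as much as the earlier swap for heptyl did, with a number 10.3 percentage points higher from compound 2 to compound 3 (beyond the scatter). The low number of compound 2 therefore does not hold for every aromatic group here, as 3-fluorophenyl and heptyl cannot be told apart, with a number 0.7 percentage points lower from compound 1 to compound 3 (within the scatter). Nothing available explains the difference between the two aromatic groups. The compounds shown leave open whether a plain phenyl, an amine or a carboxylic acid here would give a clearly higher number.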